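Trifluoromethyl for fluoro on a benzamide of a boron-containing core

The source may hold more compounds than are shown below. What is called first, only, known or untested is meant among the compounds shown, and "the series" means these compounds.

Three compounds sharing one core were examined in a functional assay on PBMC cells (Homo sapiens) for inhibition, read by HTRF, with stated times of 15 min and 24 h; a higher number here means a weaker inhibitor, a lower number a stronger inhibitor. Compound 1 `O=C(Nc1ccc2c(c1)B(O)OC2)c1ccc(C(F)(F)F)cc1F` carries a fluoro group on the benzamide ring together with a trifluoromethyl group. In this assay compound 1 gives only a limit, > 100000 nM. Compound 2 `O=C(Nc1ccc2c(c1)B(O)OC2)c1cc(C(F)(F)F)ccc1F` is built from the same atoms as compound 1, joined differently; how the two cores differ is not broken down here. In this assay compound 2 likewise gives only a limit, > 100000 nM. Compound 3 `O=C(Nc1ccc2c(c1)B(O)OC2)c1ccc(C(F)(F)F)cc1C(F)(F)F` replaces the fluoro group of compound 1 by a second trifluoromethyl group, a change described as trifluoromethyl in place of fluoro on an aromatic carbon, and in this assay compound 3 gives 8300 nM. That single replacement produced an at least 12-fold lower number from compound 1 to compound 3 (1.08 log units; beyond the scatter), a step whose lower bound is set by the limit of > 100000 nM in this assay, at which 2 of the 3 values shown sit.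

Compound 4 `O=C(Nc1ccc2c(c1)B(O)OC2)c1cc(C(F)(F)F)ccc1C(F)(F)F`, not yet measured, relates to compound 2 as compound 3 relates to compound 1: the change is trifluoromethyl in place of fluoro on an aromatic carbon. It is the same kind of change, though not the same in its surroundings: in compound 3 the entering group sits meta to a trifluoromethyl group, whereas in compound 4 it sits para to a trifluoromethyl group. Within the data shown here, compound 4 is expected to show a step of about an at least 6.6-fold lower number from compound 2 to compound 4 (0.82 log units; beyond the scatter), resting on the single measured instance, the step from compound 1 to compound 3 of an at least 12-fold lower number from compound 1 to compound 3 (1.08 log units; beyond the scatter). On that basis compound 4 is estimated to fall near 15000 nM, with a range from 4000 nM to 80000 nM expected.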

Compound 4, half-maximal inhibitory concentration: 3000 nM
Estimate against measurement, compound 4: 5.0-fold (0.70 log units) above; measured number outside the range, below it.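

Placed on a second core, trifluoromethyl in place of fluoro again lowered the number in this assay, with an at least 33-fold lower number from compound 2 to compound 4 (1.52 log units; beyond the scatter), so the step ran in the same direction on both cores shown and no compound here goes against it. Set side by side, the two steps cannot be ranked by size, and the data do not show that the change acts more strongly on one core than on the other: the same change on two cores in this assay, an at least 12-fold lower number (1.08 log units; beyond the scatter) from compound 1 to compound 3 and an at least 33-fold lower number (1.52 log units; beyond the scatter) from compound 2 to compound 4; the limit leaves it open whether they differ. Both steps start at a limit of the assay and only two cores are shown, so neither the true size of the steps nor their carrying over to a further core is settled: the limit of > 100000 nM in this assay, at which 2 of the 4 values shown sit.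

As far as these compounds go, only fluoro and trifluoromethyl are compared at this place, and what a methyl, a nitrile, an amine or a carboxylic acid would give there remains open. Every compound shown also keeps the amide link and the shared core unchanged, so how a replacement in those parts would read in this assay is open as well.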